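Replacing methoxy with 3-fluorophenyl on the core of compound 1

The source may report more compounds than this note shows. Statements on the series, on what has been measured and on what is new or still open speak of the compounds shown alone.

Compound 1 `C=C[C@@](C)(/C=C/c1ccc(OC)cc1)CCC=C(C)C` is the reference point of these notes. In a functional assay on NALM-6 cells (Homo sapiens) for cytotoxicity, with a stated time of 72 h (a lower number here means that less compound is needed, a higher number that more compound is needed for the effect), compound 1 gives only a limit, > 43400 nM, and no number; (the limit of > 43400 nM in this assay, at which 1 of the 2 values shown sits). The other measured member, compound 2 `COc1ccc(/C=C/[C@@](C)(/C=C/c2ccc(O)c(/C=C/C#N)c2)CCC=C(C)C)cc1`, gives 16500 nM in this assay, a number rather than a limit. Among the measured compounds shown here, no step connects the two measured compounds, since they differ in more than one place, so their two values show only that compound 2 sits inside the measurable range while compound 1 does not.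

The change to compound 3 `C=C[C@@](C)(/C=C/c1ccc(-c2cccc(F)c2)cc1)CCC=C(C)C` is 3-fluorophenyl in place of methoxy on an aromatic carbon. For the measured compounds named here, no measured step of this kind exists, so the size of the step from compound 1 to compound 3 in this assay can only be projected: a moderate shift toward lower concentration is expected, beyond the scatter, but with a real chance that compound 3 also ends at the limit. Compound 3 is estimated at 25000 nM, with a range of 6000 nM to 100000 nM, and the step this implies is expected to be an at least 1.7-fold lower number from compound 1 to compound 3 (0.23 log units; that floor lies within the scatter).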

Compound 3, half-maximal effective concentration: > 43400 nM
Compound 3 ended at the assay's limit (the forecaster's own chance of this, stated with the estimate: 45%); at least 1.7-fold (0.23 log units) between middle value and limit.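

Compound 1 and compound 3 both end at a limit in this assay, so the step between them cannot be read: the limit of > 43400 nM in this assay, at which 2 of the 3 values shown sit.

The compounds shown leave open whether 3-fluorophenyl in place of methoxy on an aromatic carbon changes the concentration needed for the effect at all, and if so, in which direction and by how much.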